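Trimethoxy to dimethoxy on the shared core

A few compounds are considered here, and "the series" means these few. Any claim that something is new, unique, unknown or untested is made for them only; others in the source may bear on it.

For the measured compounds named here, compound 1 `COc1cc(/C=C2\Cc3ccccc3/C(=C\c3ccc([N+](=O)[O-])cc3)C2=O)cc(OC)c1OC` is the only compound here with a number in a functional assay on HSC-3 cells (Homo sapiens) for cytotoxicity (a lower number here means that less compound is tolerated, a higher number that more compound is tolerated), where compound 1 gives 2900 nM. Compound 2 `COc1cc(/C=C2/C(=O)/C(=C/c3ccc([N+](=O)[O-])cc3)c3ccccc32)cc(OC)c1OC` gives only a limit of > 400000 nM in this assay. One of the two values shown is the limit of > 400000 nM in this assay, at which 1 of the 2 values shown sits. Compound 3 `COc1ccc(/C=C2\Cc3ccccc3/C(=C\c3ccc([N+](=O)[O-])cc3)C2=O)cc1OC` differs from compound 1 by hydrogen in place of methoxy on an aromatic carbon. Going by the values given here, no measured pair shows a change of this kind, so the step size rests on expectation alone; a modest move toward higher values, near the edge of the scatter, is expected, as a 1.6-fold higher number from compound 1 to compound 3 (0.19 log units; within the scatter). Compound 3 is expected to give 4500 nM, within 1500 nM to 14000 nM.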

Compound 3, half-maximal cytotoxic concentration: 4200 nM
Beside the measured number, compound 3's estimate is 1.1-fold (0.03 log units) above it, within the range that was stated.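

In this assay, for the compounds shown here, the pair gives the first reading of a change on the shared core: hydrogen in place of methoxy on an aromatic carbon, ortho to a methoxy group, with a 1.4-fold higher number from compound 1 to compound 3 (0.16 log units; within the scatter). Losing this one methoxy therefore leaves the read-out within the scatter. Nothing shown bears on a cause for this step. Open, going by these compounds, is whether an amine or a carboxylic acid at this position would also stay within the scatter of compound 1. A single pair also leaves open whether the step would hold elsewhere in the series.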